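Saturating the long chain of compound 2

The source may hold more compounds than are shown below. What is called first, only, known or untested is meant among the compounds shown, and "the series" means these compounds.

Measured in a functional assay on MDA-MB-231 cells (Homo sapiens) for antiproliferative activity, read by MTT assay; on this read-out higher numbers stand for weaker inhibition and lower numbers for stronger inhibition:
compound 1 `CC/C=C\C/C=C\C/C=C\CCCCCCCc1cc(=O)c2c(O)c(C)c(O)c(C)c2o1`: 6790 nM
compound 2 `CCCC/C=C\CCCCCCCCCc1cc(=O)c2c(O)c(C)c(O)c(C)c2o1`: > 87000 nM (a limit)

Compound 1 gives a measured number, 6790 nM. Compound 2 gives > 87000 nM, which is a limit and not a number. It therefore stands at the limit of > 87000 nM in this assay, at which 1 of the 2 values shown sits, and its true position in this assay is not known.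

The next compound is compound 3 `CCCCCCCCCCCCCCCc1cc(=O)c2c(O)c(C)c(O)c(C)c2o1`, which keeps the shared core and changes only the chain: hexyl in place of hex-1-en-1-yl on a saturated chain carbon, nine bonds along the chain from an aromatic carbon.

Within the data shown here, only one measured step bears on this change, an at least 12-fold higher number from compound 1 to compound 2 (1.10 log units; beyond the scatter). It is large and also alters the outer part of the chain, though not in the same way, so it is only indirect guidance. It points towards weak inhibition in the saturated chain as well, and compound 3 is expected to sit near the same limit. The expected step, a step that the limit leaves unreadable from compound 2 to compound 3, is no change beyond the scatter. For compound 3 the estimated value is 90000 nM, with an expected range of 35000 nM to 180000 nM.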

Compound 3, half-maximal inhibitory concentration: > 87000 nM
Compound 3 was reported as a limit (the forecaster's own chance of this, stated with the estimate: 70%); the middle value is on the limit's open side.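

In this assay compound 3 gives > 87000 nM, which is a limit and not a number. The step between compound 2 and compound 3 cannot be read, and compound 3 now shares its reported limit with compound 2: the limit of > 87000 nM in this assay, at which 2 of the 3 values shown sit. Compared with the only measured value among these compounds, the fully saturated chain gives an at least 12-fold higher number from compound 1 to compound 3 (1.10 log units; beyond the scatter), so replacing hex-1-en-1-yl with hexyl does not bring back a measurable value in this assay.

The compounds shown leave open whether compound 2 and compound 3 truly differ, as each is known only through a limit, and whether the double bond at this place has any effect of its own. They also leave open whether a shorter chain, or a chain ending in a hydroxyl group or a carboxylic acid, would give a measurable value on the shared core.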